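The compounds below may be only part of what the source reports. "The series", "measured", "known", "first", "only" and "open" are said of these compounds alone.

Of the compounds shown here, three built on one shared core have been tested in a functional assay on HCT-116 cells (Homo sapiens) for cytotoxicity, read by MTT assay, with a stated time of 72 h; on this read-out lower numbers stand for stronger inhibition and higher numbers for weaker inhibition. Compound 1 `Cc1cc(-c2ccccc2)n(/C(N)=N/S(=O)(=O)c2cc(C)c(Cl)cc2SCc2cccc(C(F)(F)F)c2)n1` gives 19000 nM. Compound 2 `Cc1cc(S(=O)(=O)/N=C(\N)n2nccc2-c2ccccc2)c(SCc2ccc(C(F)(F)F)cc2)cc1Cl` gives 14000 nM in this assay. Compound 3 `Cc1cc(S(=O)(=O)/N=C(\N)n2nccc2-c2ccccc2)c(SCc2cccc3ccccc23)cc1Cl` gives 7000 nM in this assay, the lowest of the three numbers. Going by the values given here, the only step between two compounds that differ in one place is a 2.0-fold lower number from compound 2 to compound 3 (0.30 log units; within the scatter), and it lies within the usual scatter of this assay. The gap from compound 1 to compound 3 lies beyond the scatter, but compound 1 also differs in its core, so no single change can be read from it.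

Compound 4 `Cc1cc(S(=O)(=O)/N=C(\N)n2nccc2-c2ccccc2)c(SCc2cccc(C(F)(F)F)c2)cc1Cl` is compound 3 with one change: 3-(trifluoromethyl)phenyl in place of naphthalen-1-yl on a saturated chain carbon bound to a sulfur. This is close to the reverse of the step already seen, in which a trifluoromethyl-bearing phenyl ring was replaced by naphthalen-1-yl and the number fell only within the scatter. Compound 1 carries the same 3-(trifluoromethyl)benzyl group on a different core and gives the highest number of the three, which weakly points the same way. Compound 4 is therefore expected to move back toward the value of compound 2, a step of a 1.9-fold higher number from compound 3 to compound 4 (0.27 log units; within the scatter) that is not expected to clear the scatter. The estimate for compound 4 is 13000 nM, with a range from 6000 nM to 28000 nM.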

Compound 4, half-maximal inhibitory concentration: 14000 nM
For compound 4 the middle estimate is 1.1-fold (0.03 log units) below the measured one; the measured number falls inside the stated range.
By their numbers in this assay, from the lowest: compounds 3, 2, 4 and 1 (each within the scatter of the next, the first and the last beyond it).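

In this assay the step from one trifluoromethyl-bearing ring to the other gives no change at the digits printed from compound 2 to compound 4 (within the scatter) and so 3-(trifluoromethyl)phenyl and 4-(trifluoromethyl)phenyl cannot be told apart on this saturated chain carbon bound to a sulfur. The exchange of naphthalen-1-yl, with its two aromatic rings, for 3-(trifluoromethyl)phenyl, with one, gives a 2.0-fold higher number from compound 3 to compound 4 (0.30 log units; within the scatter) and so, among compounds 2, 3 and 4, no group at this place stands apart from the others in this assay. Going by these compounds alone, compound 4 also gives compound 1 a partner that differs in one place for the first time: hydrogen in place of methyl on an aromatic carbon gives a 1.4-fold lower number from compound 1 to compound 4 (0.13 log units; within the scatter) and so this change on the shared core cannot be told from scatter either.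

Nothing measured here gives a reason for any of these steps. Still open, as far as these compounds go, is whether any other group at this place could move the number beyond the scatter, such as a ring carrying an amine or a carboxylic acid, or a longer chain between the sulfur and the ring.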